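The compounds below may be only part of what the source reports. "The series", "measured", "known", "first", "only" and "open" are said of these compounds alone.

In a functional assay on Ishikawa cells (Homo sapiens) for antiproliferative activity, read by CCK-8 assay, with a stated time of 48 h (on this read-out lower numbers stand for stronger inhibition and higher numbers for weaker inhibition), compound 1 `C=C(C)C(=O)NCCOc1ccc(Oc2c(-c3ccc(F)cc3)sc3cc(O)ccc23)cc1` gives > 25000 nM, which is a limit of the assay and not a number. Compound 2 `CN(C)C(=O)/C=C/CNCCOc1ccc(Oc2c(-c3ccc(F)cc3)sc3cc(O)ccc23)cc1` gives 11900 nM, and compound 3 `C/C=C/C(=O)NCCOc1ccc(Oc2c(-c3ccc(F)cc3)sc3cc(O)ccc23)cc1` gives 12400 nM. These last two values cannot be told apart, as a 1.0-fold higher number from compound 2 to compound 3 (0.02 log units; within the scatter) shows. Compound 1 is separated from them only by a bound, with an at least 2.1-fold lower number from compound 1 to compound 2 (0.32 log units; beyond the scatter) and an at least 2.0-fold lower number from compound 1 to compound 3 (0.30 log units; that floor lies within the scatter).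

Compound 4 `CN(C)C(=O)/C=C/CN1CC(Oc2ccc(Oc3c(-c4ccc(F)cc4)sc4cc(O)ccc34)cc2)C1` keeps the shared core of compound 3 but changes the group on the oxygen: 1-(3-(dimethylcarbamoyl)prop-2-en-1-yl)azetidin-3-yl in place of 2-(((prop-1-en-1-yl)carbonyl)amino)ethyl on an oxygen on an aromatic ring. The entering group holds the 3-(dimethylcarbamoyl)prop-2-en-1-yl also found in compound 2, so the nearest guide is the step between compound 2 and compound 3. That exchange on an amine nitrogen gave a 1.0-fold higher number from compound 2 to compound 3 (0.02 log units; within the scatter), which suggests that this part of the change alone should matter little. Among the measured compounds shown here, no measured compound here has the four-membered non-aromatic ring, so its contribution is unknown and the range must stay wide. In this assay, no step beyond the scatter is expected, the estimated step being a 1.6-fold lower number from compound 3 to compound 4 (0.19 log units; within the scatter). For compound 4 the expected value is 8000 nM, within an estimated range of 2500 nM to 20000 nM.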

Compound 4, half-maximal inhibitory concentration: 11200 nM
Estimate against measurement, compound 4: 1.4-fold (0.15 log units) below, and the stated range covers the measured number.
By their numbers in this assay, from the lowest: compounds 4, 2 and 3 (each within the scatter of the next). At a limit, above all of these: compound 1.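

In this assay, the four-membered non-aromatic ring of 1-(3-(dimethylcarbamoyl)prop-2-en-1-yl)azetidin-3-yl on this oxygen can stand in for either open chain without a change that can be told from the scatter, with a 1.1-fold lower number from compound 3 to compound 4 (0.04 log units; within the scatter) and a 1.1-fold lower number from compound 2 to compound 4 (0.03 log units; within the scatter). Against the methacrylamide-type chain, 2-(((1-methylethenyl)carbonyl)amino)ethyl, the same exchange gives an at least 2.2-fold lower number from compound 1 to compound 4 (0.34 log units; beyond the scatter), which lies beyond the scatter. The size of that step is only a floor, since compound 1 stands at a limit of the assay and not at a number: the limit of > 25000 nM in this assay, at which 1 of the 4 values shown sits.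

The compounds shown leave open whether a larger ring holding the nitrogen, such as a pyrrolidine or a piperidine, or a longer chain on this oxygen would move the number beyond the scatter. They also leave open whether the dimethylamide end of the entering group matters, which a carboxylic acid or a simple amine in its place would test.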